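Swapping ethyl for phenyl on the substituted nitrogen

This account rests on a few compounds, and the source may have more. Where it says the series, first, only, none or still open, it means among the compounds named here.

Measured compounds:
Compound 1, `N=C(Nc1cccc2ccccc12)Nc1cccc2ccccc12`: 165 nM
Compound 2, `CCN(C(=N)Nc1cccc2ccccc12)c1cccc2ccccc12`: 6130 nM

Both compounds were tested in an assay on membranes from brain (Cavia porcellus) for binding affinity to Sigma non-opioid intracellular receptor 1 (Homo sapiens), read by radioligand binding; on this read-out higher numbers stand for weaker inhibition and lower numbers for stronger inhibition. Compound 1 carries only hydrogen on each nitrogen of the shared core, and in this assay compound 1 gives 165 nM. Compound 2 has an ethyl group on one of those nitrogens, and in this assay compound 2 gives 6130 nM, the higher of the two numbers, so the weaker binder. Within the data shown here, the only step in the set, a 37-fold higher number from compound 1 to compound 2 (1.57 log units; beyond the scatter), came from ethyl in place of hydrogen on a nitrogen on an aromatic ring.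

Compound 3, `N=C(Nc1cccc2ccccc12)N(c1ccccc1)c1cccc2ccccc12`, has not yet been measured. It differs from compound 2 by phenyl in place of ethyl on a nitrogen on an aromatic ring. Among the measured compounds shown here, the one step on record concerns putting any group on this nitrogen, not which group; no pair shows ethyl against phenyl. Because the step of a 37-fold higher number from compound 1 to compound 2 (1.57 log units; beyond the scatter) was large, the substituted nitrogen seems to cost affinity, and a phenyl is expected to keep compound 3 near compound 2 or somewhat weaker. The expected step is a 1.3-fold higher number from compound 2 to compound 3 (0.12 log units; within the scatter). In this assay compound 3 is estimated at 8000 nM, between 2000 nM and 30000 nM.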

Compound 3, half-maximal inhibitory concentration: 7930 nM
Compound 3: the middle estimate sits 1.0-fold (0.00 log units) above what was measured, and the stated range covers the measured number.
By their numbers in this assay, from the lowest: compound 1; then compounds 2 and 3 (each within the scatter of the next).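

In this assay, replacing ethyl, with 2 heavy atoms and no ring, by phenyl, with 6 heavy atoms and an aromatic ring, on this nitrogen gives a 1.3-fold higher number from compound 2 to compound 3 (0.11 log units; within the scatter), so the two groups cannot be told apart on this read-out despite the difference in their make-up. Measured against the unsubstituted compound, phenyl in place of hydrogen gives a 48-fold higher number from compound 1 to compound 3 (1.68 log units; beyond the scatter), a large step like the one already seen for ethyl in place of hydrogen, so among these compounds the clear divide lies between hydrogen on this nitrogen and either carbon group, not between ethyl and phenyl. No measurement here explains why either group weakens binding or why the two end up so close.

Going by these compounds, it remains open whether a methyl group, the shortest carbon substituent, would already bring the same loss, and whether a longer chain such as butyl would fit the same picture. On these data alone, it is equally open whether a group carrying a hydroxyl or an amine on this nitrogen could recover any of the binding seen with hydrogen.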